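A few compounds are considered here, and "the series" means these few. Any claim that something is new, unique, unknown or untested is made for them only; others in the source may bear on it.

Compound 1, `CC(=O)N1CC[C@H](Oc2cncc(N3C(=O)c4ccc(Cl)cc4C3(C)C)c2)C1`: 7 nM
Compound 2, `CC1CN(c2cccnc2)C(=O)c2ccc(Cl)cc21`: 164 nM
Compound 3, `CC(=O)N[C@@H]1CCCc2c1cncc2N1C(=O)c2ccc(Cl)cc2[C@@H]1C`: 4 nM

All three were tested in an assay on cells for inhibition of cytochrome P450 11B2, mitochondrial (Homo sapiens), read by HTRF; a higher number here means a weaker inhibitor, a lower number a stronger inhibitor. Compound 1 holds the second highest of the three numbers; its value and that of compound 3 lie within the usual scatter of each other and cannot be told apart, while compound 2 sits well beyond the scatter with a much higher number, that is, weaker inhibition. Compound 4, `CC(=O)N1CC[C@@H](Oc2cncc(N3C(=O)c4ccc(Cl)cc4C3(C)C)c2)C1`, has not yet been measured. (the two compounds have the same atoms and bonds and differ only in configuration as drawn: 1 of 1 stereo elements differ; a stereocentre at a saturated ring carbon is drawn S in compound 1 and R in compound 4). Within the data shown here, no measured pair shows a change of this kind, so the data give no guide to its size. A change at one stereocentre can still matter; the step of a 5.7-fold higher number from compound 1 to compound 4 (0.76 log units; beyond the scatter) is expected to run toward a higher number, weaker inhibition, beyond the scatter. Compound 4 is expected to give about 40 nM, in a range from 6 nM to 400 nM.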

Compound 4, half-maximal inhibitory concentration: 11 nM
For compound 4 the middle estimate is 3.6-fold (0.56 log units) above the measured one; the range from low to high includes it.
By their numbers in this assay, from the lowest: compounds 3, 1 and 4 (each within the scatter of the next, the first and the last beyond it); then compound 2.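

In this assay, swapping S for R at this saturated ring carbon gives a 1.6-fold higher number from compound 1 to compound 4 (0.20 log units; within the scatter), so the assay cannot tell these two configurations apart. Among these compounds, the earlier compounds offered no pair differing in one place, so this is the first single change that can be read directly. The comparison is a clean one: the fact that compounds 1 and 4 differ only in the configuration as drawn

From the compounds shown here alone, it remains open whether the two configurations would stay this close if the acetyl group gave way to another group, such as an amine or a longer chain.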